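Methyl amide in place of the carboxylic acid on compound 3

The compounds below may be only part of what the source reports. "The series", "measured", "known", "first", "only" and "open" are said of these compounds alone.

Compound 3 `CC(C)[C@H]1CC[C@@]2(CO2)[C@H]2C(=O)OCC(C(=O)O)=C[C@H]12` carries a free carboxy group and in a functional assay on A549 cells (Homo sapiens) for inhibition, with a stated time of 72 h (on this read-out higher numbers stand for weaker inhibition and lower numbers for stronger inhibition), gives 458 nM. Compound 1 `CC(C)[C@H]1CC[C@@]2(CO2)[C@H]2C(=O)OCC(C(=O)OCc3ccc(-c4ccc([N+](=O)[O-])cc4)o3)=C[C@H]12` bears an ester at the same carbonyl and in this assay gives 450 nM; the two numbers lie within the usual scatter of each other, so neither compound can be set apart from the other. Compound 2 `C=C(C(=O)O)C1OC(=O)[C@H]2[C@H]1[C@@H](C(C)C)CC[C@@]2(O)CI` is reported in this assay only as a limit, > 10000 nM (the limit of > 10000 nM in this assay, at which 1 of the 3 values shown sits). Compound 4 `CNC(=O)C1=C[C@@H]2[C@@H](C(C)C)CC[C@@]3(CO3)[C@H]2C(=O)OC1` has not yet been measured. It differs from compound 3 in one place: methylamino in place of hydroxy on a carbonyl carbon. The pair compound 1 and compound 3 shows that exchanging the group on this carbonyl carbon, from an ester to carboxy, gave no change beyond the scatter, so for the methylcarbamoyl variant no step beyond the scatter is expected in either direction. The step in this assay is therefore expected to be a 1.1-fold higher number from compound 3 to compound 4 (0.04 log units; within the scatter). Compound 4 is estimated at 500 nM, with a range from 150 nM to 2000 nM.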

Compound 4, half-maximal inhibitory concentration: 5540 nM
Compound 4: middle estimate off by 11-fold (1.04 log units), on the low side; measured number above the stated range.
By their numbers in this assay, from the lowest: compounds 1 and 3 (each within the scatter of the next); then compound 4. At a limit, above all of these: compound 2.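

Methylamino in place of hydroxy on this carbonyl carbon gives a 12-fold higher number from compound 3 to compound 4 (1.08 log units; beyond the scatter) in this assay, so the group held here can matter strongly. The pair compound 1 and compound 3 showed only an exchange with no change beyond the scatter, and that tolerance does not extend to the methylcarbamoyl group of compound 4, although the counted hydrogen-bond donors and acceptors stay the same across the change. Nothing measured here bears on the reason for this step.

Still open, going by these compounds, is whether the step follows from the amide link itself or from the methyl group on its nitrogen. An unsubstituted carboxamide, a dimethylamide and a simple methyl ester on this carbonyl carbon would help separate these readings.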